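Swapping a Ring While Solubility Stays Put

The compounds below may be only part of what the source reports. "The series", "measured", "known", "first", "only" and "open" are said of these compounds alone.

Compound 2 `c1coc(CNCCCNc2ccnc3cc(CC4CCCCC4)ccc23)c1` is the starting point. In a physicochemical assay for solubility, with a stated time of 18 h, at pH 7.4 (a higher number here means a more soluble compound, a lower number a less soluble compound), compound 2 gives 4200 nM. Compound 1 `Fc1ccc(Cc2ccc3c(NCCCNCc4ccco4)ccnc3c2)c(Cl)c1` differs from it by 2-chloro-4-fluorophenyl in place of cyclohexyl on a saturated chain carbon bound to an aromatic carbon; in this assay compound 1 gives 4200 nM, and the step is no change at the digits printed from compound 2 to compound 1 (within the scatter). Compound 3 `COc1cccc(CNCCCNc2ccnc3cc(CC4CCCCC4)ccc23)c1O` carries a different core, differing from compound 2 by 2-hydroxy-3-methoxyphenyl in place of furan-2-yl on a saturated chain carbon bound to an amine nitrogen; in this assay compound 3 gives 4200 nM, a step of no change at the digits printed from compound 2 to compound 3 (within the scatter). Compound 4 `COc1cccc(CNCCCNc2ccnc3cc(Cc4ccc(F)cc4Cl)ccc23)c1O` has not yet been measured in this assay. Going by the values given here, it differs from compound 3 by 2-chloro-4-fluorophenyl in place of cyclohexyl on a saturated chain carbon bound to an aromatic carbon, the same change made at the same place as the one that took compound 2 to compound 1. Because no change at the digits printed from compound 2 to compound 1 (within the scatter) showed no movement, the expected step here is no change at the digits printed from compound 3 to compound 4 (within the scatter). The estimate for compound 4 is 4200 nM, expected to fall between 2100 nM and 8400 nM.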

Compound 4, solubility: 4200 nM
Beside the measured number, compound 4's estimate shows no gap at the digits printed, and the stated range covers the measured number.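

In this assay, putting 2-chloro-4-fluorophenyl in place of cyclohexyl gives no change at the digits printed from compound 3 to compound 4 (within the scatter) on this core, matching no change at the digits printed from compound 2 to compound 1 (within the scatter) on the other, and the furan-2-yl swap on the chlorofluorobenzyl side gives no change at the digits printed from compound 1 to compound 4 (within the scatter) for the same pair of changes. So this change carried from one core to the other with no movement on either, but a flat step repeated twice does not show that a step of real size would carry over in the same way. Nothing measured here says why the four values match.

The compounds shown leave open whether a carboxylic acid or an amine in place of cyclohexyl would shift the read-out on either core. They also leave open whether any such shift would repeat from one core to the other.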